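A few compounds are considered here, and "the series" means these few. Any claim that something is new, unique, unknown or untested is made for them only; others in the source may bear on it.

Measured so far in a functional assay for inhibition of sodium/hydrogen exchanger (Oryctolagus cuniculus); on this read-out higher numbers stand for weaker inhibition and lower numbers for stronger inhibition:
compound 1 `CCc1cc(C)c(C(=O)N=C(N)N)cc1S(C)(=O)=O`: 4.8 nM
compound 2 `Cc1cc(SC(C)(C)C)c(S(C)(=O)=O)cc1C(=O)N=C(N)N`: 22 nM
compound 3 `Cc1cc(Sc2ccccc2)c(S(C)(=O)=O)cc1C(=O)N=C(N)N`: 14 nM

Compound 3 sits second highest of the three numbers: compound 2 is nearest, a difference within the scatter, while compound 1 lies furthest, by a 2.9-fold higher number from compound 1 to compound 3 (0.46 log units; beyond the scatter). Compound 4 `Cc1cc(OC2CCCC2)c(S(C)(=O)=O)cc1C(=O)N=C(N)N` differs from compound 3 by cyclopentyloxy in place of phenylsulfanyl on an aromatic carbon. Within the data shown here, two measured steps bear on this change: a 4.6-fold higher number from compound 1 to compound 2 (0.66 log units; beyond the scatter) and a 2.9-fold higher number from compound 1 to compound 3 (0.46 log units; beyond the scatter) show that larger groups on this carbon give modestly higher numbers than ethyl, and a 1.6-fold lower number from compound 2 to compound 3 (0.20 log units; within the scatter) shows that swapping one such group for another changes little. Among the measured compounds shown here, no measured step involves an oxygen linker, so compound 4 is expected to stay near compound 3, with a step of about a 1.1-fold higher number from compound 3 to compound 4 (0.03 log units; within the scatter) in this assay, and an estimated value of 15 nM (range 5 nM to 50 nM).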

Compound 4, half-maximal inhibitory concentration: 27 nM
For compound 4 the middle estimate is 1.8-fold (0.26 log units) below the measured one; measured number inside the range.
By their numbers in this assay, from the lowest: compound 1; then compounds 3, 2 and 4 (each within the scatter of the next).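

In this assay cyclopentyloxy, the only group shown that joins this aromatic carbon through oxygen, falls level with the two sulfur-linked groups: a 1.9-fold higher number from compound 3 to compound 4 (0.29 log units; within the scatter) and a 1.2-fold higher number from compound 2 to compound 4 (0.09 log units; within the scatter) are both within the scatter. Ethyl stays apart, with a 5.6-fold higher number from compound 1 to compound 4 (0.75 log units; beyond the scatter) among these four compounds, so the change of linking atom does not bring the number back towards compound 1. Nothing shown gives a reason for this result.

As far as these compounds go, whether methoxy or an amine on this carbon would come closer to ethyl stays open.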